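Swapping benzyl for dimethylamino on compound 3

This account rests on a few compounds, and the source may have more. Where it says the series, first, only, none or still open, it means among the compounds named here.

In an ADME assay on HOS cells (Homo sapiens) for cytotoxicity, read by luminescence and ATP content, with a stated time of 48 h (on this read-out higher numbers stand for lower toxicity in this test and lower numbers for higher toxicity in this test), compound 3 (`Nc1c(C(=O)NCc2ccc(F)cc2F)c(=O)n(O)c2ncc(CCCCc3ccccc3)cc12`) gives 13000 nM and compound 2 (`Nc1c(C(=O)NCc2ccc(F)cc2F)c(=O)n(O)c2ncc(CCCCCCOCc3ccccc3)cc12`) gives 14400 nM. Going by the values given here, these are the only two actual numbers so far, and they stand level within the scatter, as a 1.1-fold lower number from compound 2 to compound 3 (0.04 log units; within the scatter) shows. Compound 1 (`CC(=O)OCCCc1cnc2c(c1)c(N)c(C(=O)NCc1ccc(F)cc1F)c(=O)n2O`) gives > 250000 nM, which is a limit of the assay and not a number.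

Compound 4 (`CN(C)CCCc1cnc2c(c1)c(N)c(C(=O)NCc1ccc(F)cc1F)c(=O)n2O`) departs from compound 3 by one change: dimethylamino in place of benzyl on a saturated chain carbon, three bonds along the chain from an aromatic carbon. Dimethylamino takes the place of benzyl on a saturated chain carbon, three bonds along the chain from an aromatic carbon, and the entering group has no ring.

Among the compounds with values here, two measured steps bear on this change. Both start from the acetoxy chain of compound 1, which also has no ring: one is an at least 19-fold lower number from compound 1 to compound 3 (1.28 log units; beyond the scatter) and the other is an at least 17-fold lower number from compound 1 to compound 2 (1.23 log units; beyond the scatter). Both are large. Read backwards, they suggest that losing the benzyl should raise the number in this assay. Dimethylamino is not acetoxy, however, so only part of that distance is expected to be recovered. The expected change is a 3.8-fold higher number from compound 3 to compound 4 (0.59 log units; beyond the scatter). Compound 4 is estimated at 50000 nM, within an expected range of 14000 nM to 200000 nM.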

Compound 4, half-maximal cytotoxic concentration: 5000 nM
Compound 4: the middle estimate sits 10-fold (1.00 log units) above what was measured; measured number below the stated range.
By their numbers in this assay, from the lowest: compound 4; then compounds 3 and 2 (each within the scatter of the next). At a limit, above all of these: compound 1.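

In this assay, going by these compounds alone, the earlier compounds showed only that two chains ending in a phenyl ring stood level with each other and far from the acetoxy chain; now a 2.6-fold lower number from compound 3 to compound 4 (0.41 log units; beyond the scatter), so a low number at this position does not require the aromatic ring of benzyl. The longer ring-bearing chain gives the same picture, with a 2.9-fold lower number from compound 2 to compound 4 (0.46 log units; beyond the scatter), which places the dimethylamino chain end of compound 4 lowest of the compounds with actual numbers. Two chain ends without a ring also lie far apart, with an at least 50-fold lower number from compound 1 to compound 4 (1.69 log units; beyond the scatter), so the absence of a ring does not by itself set the number, and this step is only a bound, since the value of compound 1 is a limit and not a number: the limit of > 250000 nM in this assay, at which 1 of the 4 values shown sits.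

The compounds shown leave open whether other ringless chain ends, such as a free hydroxyl, a carboxylic acid or a primary amine, would fall near compound 4 or near compound 1. They also leave open how the number would move if dimethylamino were carried on a shorter or a longer chain.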